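A few compounds are considered here, and "the series" means these few. Any claim that something is new, unique, unknown or untested is made for them only; others in the source may bear on it.

In an ADME assay on the whole organism (Rattus norvegicus, strain Wistar Han) for metabolic stability, read by LC-MS, with a stated time of 7 h, at a dose of 1 mg/kg by the intravenous route (on this read-out higher numbers stand for a longer-lived compound and lower numbers for a shorter-lived compound), compound 1 (`CNC(=O)c1cc(C(=O)N[C@H]2[C@@H]3COC[C@@H]32)cc2c1OC[C@@]2(C)c1ccccc1`) gives 0.3 h. Compound 2 (`CNC(=O)c1cc(C(=O)NC2CC2)cc2c1OC[C@H]2c1ccccc1`) gives 0.3 h and compound 3 (`CNC(=O)c1cc(C(=O)N[C@H]2C[C@@H]2C)cc2c1OC[C@@]2(CO)c1ccccc1`) gives 0.3 h, so compound 1 stands level with both. Among the measured compounds shown here, these three compounds do not form a pair differing in one place, so they offer no clean single-change step.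

Compound 4 (`CNC(=O)c1cc(C(=O)N[C@H]2[C@@H]3C[C@@H](O)C[C@@H]32)cc2c1OC[C@@]2(C)c1ccccc1`) keeps the core of compound 1 and changes only the group on an amide-type nitrogen: a group of 7 heavy atoms (6 carbon, 1 oxygen; one three-membered non-aromatic ring of carbon only, one five-membered non-aromatic ring of carbon only) in place of a group of 6 heavy atoms (5 carbon, 1 oxygen; one three-membered non-aromatic ring of carbon only, one five-membered non-aromatic ring with 1 hetero atom), on an amide-type nitrogen. For the measured compounds named here, no measured pair shows this exchange directly. The nearest guide is that compound 2, with another group on that nitrogen, reads 0.3 h, and compound 3, with yet another group there and a further difference elsewhere, reads 0.3 h. Neither moves away from compound 1 at 0.3 h. In this assay, the expected no change at the digits printed from compound 1 to compound 4 (within the scatter) therefore stays within the usual scatter, with no direction favoured. Compound 4 is estimated at 0.3 h, with an expected range from 0.15 h to 0.7 h.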

Compound 4, half-life: 0.7 h
Compound 4: the middle estimate sits 2.3-fold (0.37 log units) below what was measured; the range from low to high includes it.
By their numbers in this assay, from the lowest: compounds 1, 2 and 3 (each within the scatter of the next); then compound 4.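

In this assay, among the compounds shown here, the exchange on the amide-type nitrogen gives a 2.3-fold higher number from compound 1 to compound 4 (0.37 log units; beyond the scatter), the first step in this set that changes one place only, and it shows that this position can shift the half-life while the core of compound 1 stays fixed. The entering group has 1 hydrogen-bond donor where the leaving group has 0, and its five-membered ring is of carbon only where the leaving group's ring holds 1 hetero atom, so this one step cannot separate these differences. No supporting data explain the step.

The compounds shown leave open whether the ring carbon skeleton alone, without the hydroxyl, would give a similar step, and whether an amine or a carboxylic acid in the hydroxyl's place would do the same. They also leave open whether this exchange would give a similar step on a different core.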